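This account rests on a few compounds, and the source may have more. Where it says the series, first, only, none or still open, it means among the compounds named here.

Measured compounds:
compound 1, `Cc1ccccc1-c1cc(F)cc(-n2nnc(-c3ccccn3)n2)c1`, 120 nM;
compound 2, `Nc1ccccc1-c1cc(F)cc(-n2nnc(-c3ccccn3)n2)c1`, 8 nM;
compound 3, `Cc1ccc(-c2cc(F)cc(-n3nnc(-c4ccccn4)n3)c2)cn1`, 57 nM.

In a functional assay for antagonist activity at metabotropic glutamate receptor 5 (Rattus norvegicus) (on this read-out higher numbers stand for weaker inhibition and lower numbers for stronger inhibition), compound 3 gives the second highest of the three numbers; compound 1 is nearest, by a 2.1-fold lower number from compound 1 to compound 3 (0.32 log units; beyond the scatter), and compound 2 is furthest, by a 7.1-fold higher number from compound 2 to compound 3 (0.85 log units; beyond the scatter). Compound 4, `Nc1cccnc1-c1cc(F)cc(-n2nnc(-c3ccccn3)n2)c1`, has not been measured. It differs from compound 3 by 3-aminopyridin-2-yl in place of 6-methylpyridin-3-yl on an aromatic carbon. Among the measured compounds shown here, two measured steps bear on this change. The step of a 15-fold lower number from compound 1 to compound 2 (1.18 log units; beyond the scatter) shows what bringing in an amino group in place of a methyl group did on the phenyl series, and the step of a 7.1-fold higher number from compound 2 to compound 3 (0.85 log units; beyond the scatter) shows how far the 6-methylpyridin-3-yl compound sits from the amino compound. Since compound 4 again carries an amino group and a six-membered aromatic ring with one hetero atom, compound 4 is expected to give a step of a 4.8-fold lower number from compound 3 to compound 4 (0.68 log units; beyond the scatter), in the direction of compound 2. Compound 4 is therefore estimated at 12 nM, within a range of 4 nM to 40 nM.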

Compound 4, half-maximal inhibitory concentration: 19 nM
Beside the measured number, compound 4's estimate is 1.6-fold (0.20 log units) below it; low and high end bracket the measured number.
By their numbers in this assay, from the lowest: compound 2; then compound 4; then compound 3; then compound 1.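

In this assay, the amino group's low numbers are not confined to the phenyl series: compound 4, with its 3-aminopyridin-2-yl group, shows a 6.3-fold lower number from compound 1 to compound 4 (0.80 log units; beyond the scatter) and a 3.0-fold lower number from compound 3 to compound 4 (0.48 log units; beyond the scatter). Within the amino pair, the ring nitrogen of the 3-aminopyridin-2-yl group comes with a modest rise, a 2.4-fold higher number from compound 2 to compound 4 (0.38 log units; beyond the scatter), so the 2-aminophenyl group of compound 2 still gives the lowest number of the four. Nothing available here explains these differences.

Compound 3 and compound 4 differ both in the group on the ring and in where that ring holds its nitrogen, so the two contributions cannot be separated. As far as these compounds go, it also remains open whether a methylamino or hydroxyl group in place of the amino group would keep numbers this low.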